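The source may report more compounds than this note shows. Statements on the series, on what has been measured and on what is new or still open speak of the compounds shown alone.

Working notes on the series. Among the measured compounds shown here, compound 1 `NC[C@@H]1CCN(c2ccc3c(=O)c(C(=O)O)cn(Cc4ccc(-n5cccn5)cc4)c3c2)C1` is the only member with a numeric read-out: in an assay on isolated protein for inhibition of DNA topoisomerase 1 (Homo sapiens), with a stated time of 15 min (a higher number here means a weaker inhibitor, a lower number a stronger inhibitor), compound 1 gives 61000 nM. Compound 2 `NC[C@@H]1CCN(c2cc3c(cc2F)c(=O)c(C(=O)O)cn3Cc2nc(-c3ccncc3)no2)C1` reaches only the limit of the assay, and compound 2 in this assay is recorded as > 200000 nM; this reflects (the limit of > 200000 nM in this assay, at which 1 of the 2 values shown sits). Compound 1 and compound 2 differ in more than one place, so their values are shown side by side without any step being drawn between them.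

Compound 3 `NC[C@@H]1CCN(c2ccc3c(=O)c(C(=O)O)cn(Cc4ccc(-c5ccccc5)cc4)c3c2)C1` has not been measured in this assay. Relative to compound 1 the change is phenyl in place of 1H-pyrazol-1-yl on an aromatic carbon. For the measured compounds named here, no measured step speaks to this exchange, so the expected step is none beyond the scatter: compound 3 is expected to move from compound 1 by a 1.0-fold lower number from compound 1 to compound 3 (0.01 log units; within the scatter). The estimate for compound 3 in this assay is 60000 nM, with a range from 20000 nM to 180000 nM.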

Compound 3, half-maximal inhibitory concentration: 61200 nM
Compound 3: the middle estimate sits 1.0-fold (0.01 log units) below what was measured; the measured number falls inside the stated range.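

In this assay, among the compounds shown here, phenyl in place of 1H-pyrazol-1-yl on an aromatic carbon, para to a large group, gives a 1.0-fold higher number from compound 1 to compound 3 (0.00 log units; within the scatter), the first step that can be read. At this position, a six-membered aromatic ring of carbon only and a five-membered aromatic ring with 2 hetero atoms therefore read alike within the scatter, so the hydrogen-bond acceptors of the leaving group are not required for this level of inhibition. Nothing in the data shown gives a cause for this result.

Going by these compounds, it remains open whether a carboxylic acid or an aminomethyl group in this place would read the same. On these data alone, it is also open whether a plain hydrogen there, with no second aromatic ring at all, would stay within the scatter of compound 1.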